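The source may report more compounds than this note shows. Statements on the series, on what has been measured and on what is new or still open speak of the compounds shown alone.

Measured so far:
Compound 1, `O=c1cc(-n2cc(COc3ccc(F)cc3)nn2)c2ccccc2o1` — 680 nM
Compound 2, `COc1ccc2oc(=O)cc(-n3cc(COc4ccc(F)cc4)nn3)c2c1` — 3150 nM

Both were tested in a functional assay on A549 cells (Homo sapiens) for antiproliferative activity, read by MTT assay, with a stated time of 48 h; a lower number here means a stronger inhibitor, a higher number a weaker inhibitor. Among the measured compounds shown here, of the two numbers known, compound 2 has the higher one; its nearest neighbour is compound 1, and the step of a 4.6-fold higher number from compound 1 to compound 2 (0.67 log units; beyond the scatter) was the methoxy group taking the place of hydrogen on an aromatic carbon. Compound 3, `O=c1cc(-n2cc(COc3ccc(F)cc3)nn2)c2cc(O)ccc2o1`, has not yet been measured in this assay. It differs from compound 2 by hydrogen in place of methyl on an oxygen on an aromatic ring. For the measured compounds named here, no step of exactly this kind, methyl to hydrogen on an aromatic oxygen, has been measured here. Going by the values given here, the only step that bears on it is the one from compound 1 to compound 2, which shows that putting methoxy onto that carbon gave a modestly higher number. Trimming that methoxy back to hydroxy leaves a group that is neither the bare hydrogen of compound 1 nor the methoxy of compound 2, so the expected number for compound 3 lies between those two, with the step of a 2.1-fold lower number from compound 2 to compound 3 (0.32 log units; beyond the scatter) expected from compound 2 to compound 3. The estimate for compound 3 in this assay is therefore 1500 nM, within a range from 500 nM to 4500 nM.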

Compound 3, half-maximal inhibitory concentration: 2010 nM
Compound 3: the middle estimate sits 1.3-fold (0.13 log units) below what was measured, and the stated range covers the measured number.
By their numbers in this assay, from the lowest: compound 1; then compounds 3 and 2 (each within the scatter of the next).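

Swapping methoxy for hydroxy gives a 1.6-fold lower number from compound 2 to compound 3 (0.20 log units; within the scatter), so in this assay these two groups cannot be told apart, and the methyl on the oxygen makes no clear difference to the number. Hydroxy in place of hydrogen on that aromatic carbon gives a 3.0-fold higher number from compound 1 to compound 3 (0.47 log units; beyond the scatter), which means the higher number seen earlier with methoxy is not confined to that one group: both groups joined through oxygen read higher than the bare hydrogen of compound 1, and neither of the compounds carrying them goes against this. No supporting measurement is available to explain why a group on this carbon raises the number.

With only hydrogen, hydroxy and methoxy at this carbon, the data cannot show whether the rise goes with an oxygen attached there or with any group at all. An amine, a methyl or a chlorine on the same carbon, or a longer chain such as ethoxy on the oxygen, would help to separate these two readings.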